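The compounds below may be only part of what the source reports. "The series", "measured", "known", "first", "only" and "open" are said of these compounds alone.

Measured so far in an assay on HeLa cells for inhibition of sphingosine-1-phosphate transporter SPNS2 (Mus musculus), read by LC-MS, tested at 2 uM; a lower number here means less inhibition, a higher number more inhibition at the concentration tested (going by the name of the read-out):
compound 1 `CCCCCCCCCCc1ccc(-c2noc(CC3CCNC3)n2)cc1` gives 44%;
compound 2 `CCCCCCCCCCc1ccc(-c2noc(CC(O)CN3CCCCC3)n2)cc1` gives 2%.

Going by the values given here, compound 2 stands lowest of the two numbers, with compound 1 the only neighbour, well above it. Compound 3 `CCCCCCCCCCc1ccc(-c2noc(CC(O)CNCC)n2)cc1` differs from compound 2 by ethylamino in place of piperidin-1-yl on a saturated chain carbon, two bonds along the chain from an oxygen on a saturated carbon, so a six-membered non-aromatic ring gives way to a group with no ring that carries a hydrogen-bond donor. Among the compounds with values here, the one measured step, a number 42 percentage points lower from compound 1 to compound 2 (beyond the scatter), swapped the whole amine-bearing end rather than this piece alone, so it offers only a loose guide. A modest rise is expected for compound 3, a number 10 percentage points higher from compound 2 to compound 3 (within the scatter). Compound 3 is therefore estimated at 12%, within 0% to 38%.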

Compound 3, a percentage reported as inhibition, at one concentration (the size of the read-out at that concentration, not a potency): 5%
Compound 3: the middle estimate sits 7 percentage points above what was measured; low and high end bracket the measured number.
By their numbers in this assay, from the lowest: compounds 2 and 3 (each within the scatter of the next); then compound 1.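

In this assay, the step to ethylamino is a number 3 percentage points higher from compound 2 to compound 3 (within the scatter), so on this chain, losing the six-membered non-aromatic ring and gaining a hydrogen-bond donor does not separate these two compounds. The other comparison remains large, a number 39 percentage points lower from compound 1 to compound 3 (beyond the scatter), so the low reading of compound 2 is not tied to piperidin-1-yl alone. No measurement shown explains either result. Because that larger step replaces the whole amine-bearing end, it cannot show which part of the change matters. As far as these compounds go, a pyrrolidin-3-yl group carrying a hydroxyl on the chain, or a plain primary amine at this place, remains open.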